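Removing Bromo from Two Tetrafluorinated Sulfonanilides

The source may report more compounds than this note shows. Statements on the series, on what has been measured and on what is new or still open speak of the compounds shown alone.

Compound 1 `COc1ccc(NS(=O)(=O)c2c(F)c(F)c(F)c(F)c2Br)cc1` gives 160 nM in a functional assay on NCI/ADR-RES cells (Homo sapiens) for cytotoxicity; a lower number here means a stronger inhibitor of growth, a higher number a weaker inhibitor of growth. Compound 2 `COc1ccc(NS(=O)(=O)c2cc(F)c(F)c(F)c2F)cc1` gives 400 nM in this assay. The change between them is hydrogen in place of bromo on an aromatic carbon, and it made a step of a 2.5-fold higher number from compound 1 to compound 2 (0.40 log units; beyond the scatter). Compound 3 `COc1ccc(NS(=O)(=O)c2c(F)c(F)c(Br)c(F)c2F)cc1` gives 21000 nM in this assay; compound 3 and compound 1 have the same atoms joined differently, and the difference between the two cores is not broken down here.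

Compound 4 `COc1ccc(NS(=O)(=O)c2c(F)c(F)cc(F)c2F)cc1` has not yet been measured. It differs from compound 3 by hydrogen in place of bromo on an aromatic carbon. This is the same kind of change as that from compound 1 to compound 2, not the same one: in compound 3 the carbon is ortho to two fluoro groups, meta to two fluoro groups and para to a large group, whereas in compound 1 it is ortho to a fluoro group, ortho to a large group, meta to two fluoro groups and para to a fluoro group. The earlier step alone would point to a weaker compound 4, yet the values of compound 2 at 400 nM and compound 3 at 21000 nM pull the other way, so compound 4 is expected to move by a 5.3-fold lower number from compound 3 to compound 4 (0.72 log units; beyond the scatter). Compound 4 is estimated at 4000 nM, between 500 nM and 40000 nM.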

Compound 4, concentration for 50% growth inhibition: > 50000 nM
Compound 4 gave a limit, no number; the forecaster's own chance of this, stated with the estimate: 10%; middle value at least 12-fold (1.09 log units) from the limit.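

In this assay compound 4 gives > 50000 nM, which is a limit of the assay and not a number. Hydrogen in place of bromo makes a step of an at least 2.3-fold higher number from compound 3 to compound 4 (0.37 log units; beyond the scatter), so the change moves the number the same way on the core of compound 3 as on the core of compound 1, and the two steps cannot be told apart: the same change on two cores in this assay, a 2.5-fold higher number (0.40 log units; beyond the scatter) from compound 1 to compound 2 and an at least 2.3-fold higher number (0.37 log units; beyond the scatter) from compound 3 to compound 4; the limit leaves it open whether they differ This shows that the direction of the change carried over between these two cores, but it does not show that the size of the step is equal on both, and two cores are too few to set a rule for the series, with one of the values resting on a limit: the limit of > 50000 nM in this assay, at which 1 of the 4 values shown sits.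

The compounds shown leave open whether a group other than bromo or hydrogen at these places, such as chloro or methyl, would give a stronger or a weaker inhibitor of growth on either core. They also leave open how either core would respond to an amine or a carboxylic acid in the same place.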